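A few compounds are considered here, and "the series" means these few. Any claim that something is new, unique, unknown or untested is made for them only; others in the source may bear on it.

The measured compounds in this study:

Compound 1, `CCC(=O)N(Cc1ccc(OC)c(O)c1)c1cc(OC)c(OC)c(OC)c1`, 50 nM
Compound 2, `C/C=C/C(=O)N(Cc1cc(OC)c(OC)c(OC)c1)c1ccc(OC)c(O)c1`, 6150 nM
Compound 3, `C/C=C/C(=O)N(Cc1ccc(OC)cc1)c1cc(OC)c(OC)c(OC)c1`, 450 nM

All three were tested in a functional assay on MGC-803 cells (Homo sapiens) for inhibition, read by MTT assay, with a stated time of 48 h; a lower number here means a stronger inhibitor, a higher number a weaker inhibitor. Among them compound 1 stands at the lowest number; compound 3 comes nearest to it, with a gap beyond the usual scatter, and compound 2 lies furthest away, also beyond it. Compound 4, `COc1ccc(CN(C(=O)C(C)C)c2cc(OC)c(OC)c(OC)c2)cc1O`, has not yet been measured there. It differs from compound 1 in a single place: methyl in place of hydrogen on a saturated chain carbon bound to a carbonyl carbon and a saturated chain carbon. The acyl chain grows from propanoyl to isopropylcarbonyl while everything else in the molecule is kept. Within the data shown here, no pair among the measured compounds differs in this one place, so the data give no direct guide to the size of the step. The change is small and does not touch the two aromatic parts, so the author expects the step of a 1.6-fold higher number from compound 1 to compound 4 (0.20 log units; within the scatter) to be small, toward a somewhat higher number, likely within the scatter. Compound 4 is therefore estimated at 80 nM, within a range of 25 nM to 300 nM.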

Compound 4, half-maximal inhibitory concentration: 210 nM
The estimate for compound 4 lay 2.6-fold (0.42 log units) below the measured number, within the range that was stated.
By their numbers in this assay, from the lowest: compound 1; then compound 4; then compound 3; then compound 2.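

Methyl in place of hydrogen on this saturated chain carbon gives a 4.2-fold higher number from compound 1 to compound 4 (0.62 log units; beyond the scatter) in this assay, so a single added carbon on the acyl chain moves the number beyond the usual scatter while both aromatic parts stay the same. Among these compounds, this is the first direct reading of this position, as no earlier pair differed in one place only, and it puts the propanoyl of compound 1 ahead of the isopropylcarbonyl of compound 4. No measurement bears on why the number rises with this change.

The compounds shown leave open whether branching or the added carbon itself governs the step, which a straight butanoyl chain would separate from the isopropylcarbonyl of compound 4. They also leave open how an acetyl group or a cyclopropyl group on the carbonyl would compare with the propanoyl of compound 1.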